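A few compounds are considered here, and "the series" means these few. Any claim that something is new, unique, unknown or untested is made for them only; others in the source may bear on it.

Measured in a functional assay on MRC5 cells (Homo sapiens) for inhibition, read by microscopy and resazurin assay, with a stated time of 72 h; on this read-out lower numbers stand for stronger inhibition and higher numbers for weaker inhibition:
- compound 1 `C=CCONC(=O)CN1C(=O)S/C(=C\c2cccc(C(=O)N[C@H](C(=O)OC)C(C)C)c2)C1=O`: > 128000 nM, a limit of the assay
- compound 2 `C=CCONC(=O)Cn1cc(C(=O)NCC(=O)N[C@H](C(=O)O)C(C)C)c2ccccc21`: > 128000 nM, a limit of the assay
- compound 3 `C=CCONC(=O)Cn1cc(C(=O)NCC(=O)N[C@@H](CC(C)C)C(=O)O)c2ccccc21`: > 128000 nM, a limit of the assay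

Compound 2 stands only at the limit of this assay, so no number is known for it. Compound 4 `C=CCONC(=O)Cn1cc(C(=O)N[C@@H](C)C(=O)N[C@H](C(=O)O)C(C)C)c2ccccc21` differs from compound 2 by methyl in place of hydrogen on a saturated chain carbon bound to an amide-type nitrogen and a carbonyl carbon. Going by the values given here, the single measured step that bears on this position, a step that the two limits leave unreadable from compound 2 to compound 3, is unreadable because both values sit at the limit of > 128000 nM in this assay, at which 3 of the 3 values shown sit. No readable step gives a size or a direction, so the expected step is a step that the limit leaves unreadable from compound 2 to compound 4, which rests on nothing beyond the shared limit. Compound 4 is therefore estimated at 200000 nM in this assay, within 60000 nM to 700000 nM, most probably reported again as a limit.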

Compound 4, half-maximal inhibitory concentration: > 128000 nM
Compound 4 was reported as a limit; the forecaster's own chance of this, stated with the estimate: 85%; the middle value is on the limit's open side.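

In this assay compound 4 gives > 128000 nM as a limit of the assay. No new step can be read from compound 2 and compound 4, which sit at the same limit: the limit of > 128000 nM in this assay, at which 4 of the 4 values shown sit.
The compounds shown leave open what size or direction the change from hydrogen to methyl has on this read-out.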